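The compounds below may be only part of what the source reports. "The series", "measured", "known", "first", "only" and "open" are said of these compounds alone.

Measured in a functional assay on HepG2 cells (Homo sapiens) for inhibition, read by MTT assay, with a stated time of 48 h; a lower number here means a stronger inhibitor, a higher number a weaker inhibitor:
- compound 1 `Cc1ccc(/C=C2\SC(=O)N(CCNC(=O)Nc3c(C)n(C)n(-c4ccccc4)c3=O)C2=O)cc1`: 25700 nM
- compound 2 `COc1cc(/C=C2\SC(=O)N(CCNC(=O)Nc3c(C)n(C)n(-c4ccccc4)c3=O)C2=O)cc(OC)c1OC`: 10800 nM
- compound 3 `COc1ccc(/C=C2\SC(=O)N(CC(=O)Nc3c(C)n(C)n(-c4ccccc4)c3=O)C2=O)cc1`: 68500 nM

Of these three, compound 3 has the highest number, 68500 nM, which makes it the weakest inhibitor so far. Compound 4 `Cc1c(NC(=O)CN2C(=O)S/C(=C\c3ccc(Cl)cc3)C2=O)c(=O)n(-c2ccccc2)n1C` has chloro in place of methoxy on an aromatic carbon, para to a large group (chloro in place of methoxy on an aromatic carbon). The closest evidence is a 2.4-fold lower number from compound 1 to compound 2 (0.38 log units; beyond the scatter), where 3,4,5-trimethoxyphenyl replaces 4-methylphenyl. Among the compounds with values here, that step is modest, and no measured pair swaps methoxy for chloro, so no step beyond the scatter is expected in this assay. The estimated step is a 1.4-fold lower number from compound 3 to compound 4 (0.14 log units; within the scatter). For compound 4 the estimated value is 50000 nM, with an expected range of 20000 nM to 110000 nM.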

Compound 4, half-maximal inhibitory concentration: 31900 nM
Compound 4: the middle estimate sits 1.6-fold (0.20 log units) above what was measured; the measured number falls inside the stated range.
By their numbers in this assay, from the lowest: compound 2; then compounds 1 and 4 (each within the scatter of the next); then compound 3.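

Replacing methoxy with chloro on the aromatic ring gives a 2.1-fold lower number from compound 3 to compound 4 (0.33 log units; beyond the scatter) in this assay, so this single position, para to a large group, affects the result, though only modestly. The earlier step changed the whole aryl group, from 4-methylphenyl to 3,4,5-trimethoxyphenyl, whereas this one exchanges a single group. No measurement here gives a reason for this step. On these data alone, whether fluoro, bromo or an amine at this place would shift the number remains open. So does whether the same swap would have a similar effect on the different chain carried by compound 1 and compound 2.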